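Replacing the acidic ring of compound 3 with methylcarbamoyl

The compounds below may be only part of what the source reports. "The series", "measured", "known", "first", "only" and "open" are said of these compounds alone.

Compound 3 `Cc1ccc(-c2nc(=O)s[nH]2)c(-c2ccc([C@@H](C)N(CC3CC3)c3nc(C(=O)NS(=O)(=O)C4CC4)c(C4CC4)s3)cc2)c1` gives the highest exposure of the three measured compounds: in an ADME assay on the whole organism (Macaca fascicularis) for pharmacokinetics, at a dose of 1 mg/kg by the oral route (on this read-out higher numbers stand for higher exposure at the dose given and lower numbers for lower exposure), compound 3 reaches 6590 nM. Compound 2 `CCS(=O)(=O)NC(=O)c1nc(N(CC2CC2)[C@H](C)c2ccc(-c3cc(Cl)ccc3-c3nc(=O)o[nH]3)cc2)sc1C` gives 1190 nM, and compound 1 `Cc1sc(N(CC2CC2)[C@H](C)c2ccc(-c3cc(Cl)ccc3-c3nc(=O)o[nH]3)cc2)nc1C(=O)NS(C)(=O)=O` gives 367 nM. Going by the values given here, the only one-place step among them, a 3.2-fold higher number from compound 1 to compound 2 (0.51 log units; beyond the scatter), concerns the sulfonyl substituent, not the ring that changes here. Compound 4 `CNC(=O)c1ccc(C)cc1-c1ccc([C@@H](C)N(CC2CC2)c2nc(C(=O)NS(=O)(=O)C3CC3)c(C3CC3)s2)cc1` differs from compound 3 as follows: a group of 4 heavy atoms (2 carbon, 1 nitrogen, 1 oxygen; no ring) in place of a group of 6 heavy atoms (2 carbon, 2 nitrogen, 1 oxygen, 1 sulfur; one five-membered aromatic ring with 3 hetero atoms), on an aromatic carbon. Among the compounds with values here, no measured step covers this change, so the expectation rests only on the spread of the three numbers. Compound 4 is expected to give 3000 nM, within 800 nM to 12000 nM, and the expected step is a 2.2-fold lower number from compound 3 to compound 4 (0.34 log units; beyond the scatter).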

Compound 4, maximal plasma concentration: 4740 nM
Compound 4: middle estimate off by 1.6-fold (0.20 log units), on the low side; measured number inside the range.
By their numbers in this assay, from the lowest: compound 1; then compound 2; then compounds 4 and 3 (each within the scatter of the next).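

In this assay, methylcarbamoyl in place of the five-membered aromatic ring on this aromatic carbon gives a 1.4-fold lower number from compound 3 to compound 4 (0.14 log units; within the scatter), so the two compounds cannot be told apart. Going by these compounds alone, at this position, then, a smaller group with no ring can stand in for the ring without a change beyond the scatter, something the sulfonyl step among the earlier compounds could not show. No measurement shown here bears on the reason for this result. As far as these compounds go, whether a carboxylic acid or a longer chain on the amide nitrogen would fare the same on this carbon remains open, as does whether this swap would hold on the core of compound 2.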